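A few compounds are considered here, and "the series" means these few. Any claim that something is new, unique, unknown or untested is made for them only; others in the source may bear on it.

Of the compounds shown here, three sharing one core have been measured in an ADME assay on a cell-free system (plasma, Homo sapiens) for protein binding. Compound 1 `Cc1cc(Nc2ccc(C(F)(F)F)cc2)n2nc(CCO)nc2n1`, carrying 2-hydroxyethyl, gives 67%. Compound 2 `CSc1nc2nc(C)cc(Nc3ccc(C(F)(F)F)cc3)n2n1`, carrying methylsulfanyl, gives 91.8%. Compound 3 `COCCc1nc2nc(C)cc(Nc3ccc(C(F)(F)F)cc3)n2n1`, carrying 2-methoxyethyl, gives 73.7%, which lies within the scatter of compound 1 and clearly apart from compound 2.

Compound 4 `CCc1nc2nc(C)cc(Nc3ccc(C(F)(F)F)cc3)n2n1` turns 2-methoxyethyl into ethyl, with hydrogen in place of methoxy on a saturated chain carbon, two bonds along the chain from an aromatic carbon. Among the measured compounds shown here, no measured step removes that oxygen outright, so the evidence is indirect. Putting methyl on the chain oxygen gave a 1.3-fold lower unbound fraction from compound 1 to compound 3 (0.10 log units; within the scatter), so changing the end of that chain moved little there. Exchanging the whole group gave a 3.2-fold higher unbound fraction from compound 2 to compound 3 (0.51 log units; beyond the scatter), a modest step. Compound 4 lacks oxygen in this group, as does compound 2 at 91.8%, so a shift in that direction seems likely. The step expected is therefore a 2.2-fold lower unbound fraction from compound 3 to compound 4 (0.34 log units; beyond the scatter), modest and toward less free compound. The estimate for compound 4 is 88%, with an expected range of 78% to 94%.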

Compound 4, plasma protein binding in the plasma assay: 87.5%
For compound 4 the middle estimate is 1.0-fold (0.02 log units) (unbound fraction) below the measured one, within the range that was stated.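

In the plasma assay the first direct removal of the chain oxygen gives a 2.1-fold lower unbound fraction from compound 3 to compound 4 (0.32 log units; beyond the scatter) and, from the hydroxy end, a 2.6-fold lower unbound fraction from compound 1 to compound 4 (0.42 log units; beyond the scatter), so this chain carbon responds to losing the oxygen-bearing end even though capping hydroxy with methyl gave a 1.3-fold lower unbound fraction from compound 1 to compound 3 (0.10 log units; within the scatter). Among these four compounds, those without oxygen in this group read alike, with a 1.5-fold higher unbound fraction from compound 2 to compound 4 (0.18 log units; within the scatter), as do the two with oxygen, and none goes against this. In a physicochemical assay for solubility, at pH 6.5 (a lower number here means a less soluble compound, a higher number a more soluble compound), compound 3 gives 71000 nM and compound 4 gives 39000 nM, the same change gives a 1.8-fold lower number from compound 3 to compound 4 (0.26 log units; within the scatter), and nothing shown explains either shift.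

Still open, on these data alone, is whether the oxygen itself or the length of the chain governs the step; this change alters both at once. A propyl group or an amine at the chain end could help separate these two readings.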